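The source may hold more compounds than are shown below. What is called first, only, known or untested is meant among the compounds shown, and "the series" means these compounds.

The series shares one core, varied at two aryl positions. Compound 1 `CC(c1ccc(-c2ccccc2)c(F)c1)c1nnc2n1N=C(c1ccc(Cl)cc1)CS2` gives 3900 nM in a functional assay on Huh-7 cells (Homo sapiens) for inhibition, read by sulforhodamine B assay, with a stated time of 72 h (on this read-out higher numbers stand for weaker inhibition and lower numbers for stronger inhibition), compound 3 `CC(C)Cc1ccc(C(C)c2nnc3n2N=C(c2ccc(OC(F)(F)F)cc2)CS3)cc1` gives 3600 nM in this assay, and compound 2 `COc1ccc2cc(C(C)c3nnc4n3N=C(c3ccc(C(F)(F)F)cc3)CS4)ccc2c1` gives 14800 nM in this assay. Among these three numbers compound 2 stands highest: its number lies beyond the scatter above both compound 1 and compound 3, so on this read-out compound 2 inhibits least strongly of the three. No two of the measured compounds differ in a single place, so no clean step can be read from them; compounds 1 and 3 each differ from compound 2 at both aryl positions at once.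

The step to compound 4 `COc1ccc2cc(C(C)c3nnc4n3N=C(c3ccc(Br)cc3)CS4)ccc2c1` changes only one of them: bromo in place of trifluoromethyl on an aromatic carbon, on an aromatic carbon of a six-membered aromatic ring of carbon only, para to a large group. The change is small in atom count, a single heavy atom replacing four. Compound 1 carries a halogen at the matching position and sits lower than compound 2, but its other aryl differs too, so the halogen's contribution cannot be isolated. A modest move toward lower numbers is expected, of the size a 1.9-fold lower number from compound 2 to compound 4 (0.27 log units; within the scatter), though it could well stay within the scatter. Compound 4 is expected to give about 8000 nM in this assay, between 3000 nM and 20000 nM.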

Compound 4, half-maximal inhibitory concentration: 9300 nM
Compound 4: middle estimate off by 1.2-fold (0.07 log units), on the low side; low and high end bracket the measured number.
By their numbers in this assay, from the lowest: compounds 3 and 1 (each within the scatter of the next); then compounds 4 and 2 (each within the scatter of the next).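

this assay records a 1.6-fold lower number from compound 2 to compound 4 (0.20 log units; within the scatter) when 4-(trifluoromethyl)phenyl becomes 4-bromophenyl and the rest of the molecule stays fixed. Going by these compounds alone, this is the first step that changes one place alone, and so the first direct look at this aromatic carbon. The step lies within the scatter, so this read-out does not tell a trifluoromethyl group of four heavy atoms from a bromo group of one at this position in this pair, and nothing measured here bears on why the two read alike.

Compounds 1 and 3 carry other groups at this position, chloro and trifluoromethoxy, but each also differs in its other aryl group, so steps to them cannot be read and the contribution of each group stays unresolved. The compounds shown also leave open how this position would respond to a group of a different kind, such as an amine, a carboxylic acid or a nitrile, and whether the change from trifluoromethyl to bromo would read the same with a different aryl group on the other side of the shared core.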